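From methyl to trifluoromethyl: compound 3 and compound 4

This account rests on a few compounds, and the source may have more. Where it says the series, first, only, none or still open, it means among the compounds named here.

The series shares the core of compound 1 (`COc1cccc(S(=O)(=O)c2cccc(N)c2C#N)c1`). In a functional assay on MT4 cells (Homo sapiens) for cytotoxicity (a higher number here means a weaker inhibitor, a lower number a stronger inhibitor), compound 1 reads > 200000 nM, which is a limit of the assay and not a number. Compound 2 (`Cc1cccc(S(=O)(=O)c2cccc(N)c2C#N)c1`) gives 179000 nM. Compound 3 (`COc1cc(C)cc(S(=O)(=O)c2cccc(N)c2C#N)c1`) gives 94000 nM. Going by the values given here, these are the only two true numbers so far, and between them stands a 1.9-fold lower number from compound 2 to compound 3 (0.28 log units; within the scatter), so compound 3 stands with compound 2 and not apart from it.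

Compound 4 (`COc1cc(C(F)(F)F)cc(S(=O)(=O)c2cccc(N)c2C#N)c1`) carries one change from compound 3: trifluoromethyl in place of methyl on an aromatic carbon. Among the compounds with values here, no measured step tests trifluoromethyl. The closest one puts methyl in place of hydrogen on an aromatic carbon, and it is an at least 2.1-fold lower number from compound 1 to compound 3 (0.32 log units; beyond the scatter). Methyl in place of methoxy gives an at least 1.1-fold lower number from compound 1 to compound 2 (0.04 log units; that floor lies within the scatter). Both steps start from a limit, so they fix a direction only loosely: toward a lower number, and by a modest amount at best. A small step in that same direction is therefore expected in this assay. The expected move is a 1.3-fold lower number from compound 3 to compound 4 (0.13 log units; within the scatter). For compound 4 the estimated value is 70000 nM, with an expected range of 30000 nM to 170000 nM.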

Compound 4, half-maximal inhibitory concentration: 164000 nM
Estimate against measurement, compound 4: 2.3-fold (0.37 log units) below; measured number inside the range.
By their numbers in this assay, from the lowest: compounds 3, 4 and 2 (each within the scatter of the next). At a limit, above all of these: compound 1.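

Trifluoromethyl in place of methyl is now tested directly at this position, meta to a large group and meta to a methoxy group: in this assay, there is a 1.7-fold higher number from compound 3 to compound 4 (0.24 log units; within the scatter). The entering group has 4 heavy atoms against 1 for methyl, yet this change does not separate compound 4 from compound 3 beyond the scatter, so the series shows no clear effect of this exchange at this position. The comparison with hydrogen at the same position, an at least 1.2-fold lower number from compound 1 to compound 4 (0.08 log units; that floor lies within the scatter), is only a floor that lies within the scatter and gives no true size for the step: the limit of > 200000 nM in this assay, at which 1 of the 4 values shown sits.

From the compounds shown here alone, whether an amine, a carboxylic acid or a longer chain at this position would move the number beyond the scatter remains open. Also open is what the methoxy group contributes when trifluoromethyl is present, as no pair shown isolates that single change.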